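Working notes: Vero cell cytotoxicity in one series

The source may hold more compounds than are shown below. What is called first, only, known or untested is meant among the compounds shown, and "the series" means these compounds.

Measured so far in an ADME assay on Vero cells (Chlorocebus sabaeus) for cytotoxicity, read by resazurin assay, with a stated time of 3 days; a lower number here means a stronger inhibitor, a higher number a weaker inhibitor:
compound 1 `CCCCNC(=O)Nc1cc2nc(C3CCCCC3)[nH]c2cc1N(CC)CC`: > 100 ug/mL
compound 2 `CN(C)c1cc2[nH]c(C3CCCCC3)nc2cc1NC(=O)c1ccc(Br)cc1`: > 100 ug/mL
compound 3 `COc1ccc(C(=O)Nc2cc3nc(C4CCCCC4)[nH]c3cc2N2CCCC2)cc1`: > 100 ug/mL

In this assay compound 1 gives only a limit, > 100 ug/mL, and not a number. Compound 2 likewise sits at a limit, > 100 ug/mL. Compound 3 also sits at a limit, > 100 ug/mL. Within the data shown here, since all three values are limits, no step between measured compounds can be counted, and compound 1 cannot be placed relative to the others: the limit of > 100 ug/mL in this assay, at which 3 of the 3 values shown sit, so the three are indistinguishable in this assay.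

The next compound, compound 4 `CCN(CC)c1cc2[nH]c(C3CCCCC3)nc2cc1NC(=O)c1ccc(OC(F)(F)F)cc1`, differs from compound 1 in one place: 4-(trifluoromethoxy)phenyl in place of butylamino on a carbonyl carbon. Among the measured compounds shown here, no measured step speaks to this change. Given that compound 1 and both other measured compounds sit at the limit, the expected step in this assay is a number no higher from compound 1 to compound 4 (the limit leaves the size open), none beyond the scatter. Compound 4 is therefore estimated at 100 ug/mL, between 40 ug/mL and 200 ug/mL, most likely reported again only as the limit.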

Compound 4, half-maximal inhibitory concentration: > 100 ug/mL
Compound 4: no number, only a limit; the forecaster's own chance of this, stated with the estimate: 80%; the middle value sits exactly at the limit.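

In this assay compound 4 gives > 100 ug/mL, a limit and not a number. Compound 1 also gives only a limit, so no step between compound 1 and compound 4 can be read: the limit of > 100 ug/mL in this assay, at which 4 of the 4 values shown sit.

The compounds shown leave open what numerical value any of them would have in this assay, and whether butylamino or 4-(trifluoromethoxy)phenyl on the carbonyl carbon makes any difference there.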